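This account rests on a few compounds, and the source may have more. Where it says the series, first, only, none or still open, it means among the compounds named here.

Measured so far in an assay on U2OS cells for activation of nuclear factor erythroid 2-related factor 2 (Homo sapiens), read by chemiluminescence, with a stated time of 6 h; on this read-out higher numbers stand for an effect only at larger amounts of compound and lower numbers for an effect already at smaller amounts:
compound 1 `COc1ccccc1S(=O)(=O)/C=C/c1ccccn1` gives 9070 nM
compound 2 `COc1cccc(S(=O)(=O)/C=C/c2ccccn2)c1` gives 2170 nM
compound 3 `COc1ccccc1S(=O)(=O)/C=C/c1cccnc1` gives > 10000 nM

The value of compound 3 is a limit of this assay, not a number; (the limit of > 10000 nM in this assay, at which 1 of the 3 values shown sits). Compound 4 `COc1cccc(S(=O)(=O)/C=C/c2cccnc2)c1` has not been measured in this assay.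

From compound 1 to compound 3 the change is pyridin-3-yl in place of pyridin-2-yl on a double-bonded chain carbon bound to a double-bonded chain carbon, which gave an at least 1.1-fold higher number from compound 1 to compound 3 (0.04 log units; that floor lies within the scatter). The same change leads from compound 2 to compound 4: pyridin-3-yl in place of pyridin-2-yl on a double-bonded chain carbon bound to a double-bonded chain carbon. The difference between the core of compound 1 and the core of compound 2 is not broken down here; in this assay compound 2 gives 2170 nM where compound 1 gives 9070 nM.

From the compounds shown here alone, for compound 4 a step of a 2.8-fold higher number from compound 2 to compound 4 (0.44 log units; beyond the scatter) is expected in this assay, a larger shift than the floor seen because the step of an at least 1.1-fold higher number from compound 1 to compound 3 (0.04 log units; that floor lies within the scatter) ends at a limit and its true size is unknown. Compound 4 is estimated at 6000 nM, between 2500 nM and 15000 nM.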

Compound 4, half-maximal effective concentration: 6290 nM
Compound 4: the middle estimate sits 1.0-fold (0.02 log units) below what was measured, within the range that was stated.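

In this assay, pyridin-3-yl in place of pyridin-2-yl on a double-bonded chain carbon bound to a double-bonded chain carbon gives a 2.9-fold higher number from compound 2 to compound 4 (0.46 log units; beyond the scatter), a modest but readable loss on the core of compound 2. Compound 3 gives > 10000 nM, which is a limit of the assay and not a number. Whether the change carries over from one core to another at the same size is therefore not shown: the same change on two cores in this assay, an at least 1.1-fold higher number (0.04 log units; that floor lies within the scatter) from compound 1 to compound 3 and a 2.9-fold higher number (0.46 log units; beyond the scatter) from compound 2 to compound 4; the limit leaves it open whether they differ

The compounds shown leave open how a phenyl ring or a carboxylic acid would read in that same place. They also leave open whether this change would give a readable step on any further core.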